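This account rests on a few compounds, and the source may have more. Where it says the series, first, only, none or still open, it means among the compounds named here.

Compound 1: `O=C(C1CCC1)N1CC2CC(C1)N2`, 11000 nM
Compound 2: `O=C([C@H]1C[C@H]1F)N1CC2CC(C1)N2`, 1500 nM

In an assay on SH-EP1 cells for agonist activity at Neuronal acetylcholine receptor; alpha4/beta2 (Homo sapiens), read by FLIPR and calcium flux (a higher number here means that more compound is needed for the effect, a lower number that less compound is needed), compound 2 shows the lowest number of the two measured, after the change a 7.3-fold lower number from compound 1 to compound 2 (0.87 log units; beyond the scatter). Compound 3 `O=C([C@H]1C[C@@H]1F)N1CC2CC(C1)N2` keeps everything in place: the two compounds have the same atoms and bonds; at least one stereo element is drawn with a configuration in one of them and without one in the other: 1 of 4 stereo elements differ; a stereocentre at a saturated ring carbon is drawn R in compound 2 and S in compound 3. Within the data shown here, no measured step involves a change of configuration alone; the one step known swaps one ring for another, so it gives no direct guide. The expected step is a 2.0-fold higher number from compound 2 to compound 3 (0.30 log units; within the scatter), most likely towards a higher number or none beyond the scatter. Compound 3 is estimated at 3000 nM, with a range from 800 nM to 15000 nM.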

Compound 3, half-maximal effective concentration: 2800 nM
Compound 3: the middle estimate sits 1.1-fold (0.03 log units) above what was measured; low and high end bracket the measured number.
By their numbers in this assay, from the lowest: compounds 2 and 3 (each within the scatter of the next); then compound 1.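

In this assay, redrawing a stereocentre at a saturated ring carbon from R to S gives a 1.9-fold higher number from compound 2 to compound 3 (0.27 log units; within the scatter), so this change of configuration makes no clear difference here. The 2-fluorocyclopropyl group in place of cyclobutyl gives a 3.9-fold lower number from compound 1 to compound 3 (0.59 log units; beyond the scatter), so the lower number seen against compound 1 holds for compound 3 as well. This reading of the configuration stays cautious because of one point: the fact that one of compounds 2 and 3 is drawn with a defined configuration and the other without, at the place where they differ

The compounds shown leave open whether the fluorine itself matters. A plain cyclopropyl or a 2-methylcyclopropyl group on the carbonyl would address that question.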